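From Compound 3 to Compound 4: Cyclopropyl in Place of Isopropyl

The source may hold more compounds than are shown below. What is called first, only, known or untested is meant among the compounds shown, and "the series" means these compounds.

Compound 1 `CC1CC/C(=N\Nc2ccc(C(F)(F)F)cc2)c2ncc(C(=O)O)c(=O)n21`: 38.6 umol/kg
Compound 2 `CC(=O)c1ccc(N/N=C2\CCC(C)n3c2ncc(C(=O)O)c3=O)cc1`: 9.5 umol/kg
Compound 3 `CC(C)c1ccc(N/N=C2\CCC(C)n3c2ncc(C(=O)O)c3=O)cc1`: 2.4 umol/kg

All three were measured in a functional assay on the whole organism for inhibition, with Rattus norvegicus as the target; on this read-out higher numbers stand for an effect only at larger amounts of compound and lower numbers for an effect already at smaller amounts. Compound 3 gives the lowest of the three numbers; the nearest step is a 4.0-fold lower number from compound 2 to compound 3 (0.60 log units; beyond the scatter) and the widest is a 16-fold lower number from compound 1 to compound 3 (1.21 log units; beyond the scatter). Compound 4 `CC1CC/C(=N\Nc2ccc(C3CC3)cc2)c2ncc(C(=O)O)c(=O)n21` has not been measured. It differs from compound 3 in one place: cyclopropyl in place of isopropyl on an aromatic carbon. For the measured compounds named here, no measured step involves a cyclopropyl, so none bears on this change directly; the two steps leading to compound 3 show only that the isopropyl compound gave the lowest number. Compound 4 is therefore expected to show a 1.3-fold higher number from compound 3 to compound 4 (0.10 log units; within the scatter), a step not beyond the scatter. The estimate for compound 4 in this assay is 3 umol/kg, with a range from 1.2 umol/kg to 8 umol/kg.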

Compound 4, dose for 50% inhibition: 41.1 umol/kg
The estimate for compound 4 lay 14-fold (1.14 log units) below the measured number; the whole stated range lies below it.
By their numbers in this assay, from the lowest: compound 3; then compound 2; then compounds 1 and 4 (each within the scatter of the next).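

Cyclopropyl in place of isopropyl at this aromatic carbon adds only a three-membered non-aromatic ring, yet in this assay it gives a 17-fold higher number from compound 3 to compound 4 (1.23 log units; beyond the scatter), so a small carbon group here does not by itself bring the low number. Cyclopropyl also gives a 4.3-fold higher number from compound 2 to compound 4 (0.64 log units; beyond the scatter), while a 1.1-fold higher number from compound 1 to compound 4 (0.03 log units; within the scatter) stays within the scatter, leaving isopropyl alone with the lowest number among these four groups. Nothing available explains this gap. From the compounds shown here alone, whether ethyl, tert-butyl or methoxy at this place would keep the number of compound 3 2.4 umol/kg remains open.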